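Propyl to benzyl on the shared core: working notes

The source may hold more compounds than are shown below. What is called first, only, known or untested is meant among the compounds shown, and "the series" means these compounds.

Measured compounds
compound 1 `CCC[C@@H]1O[C@H](COCc2ccccc2)[C@@H](OCc2ccccc2)[C@H](OCc2ccccc2)[C@H]1O` gives 18900 nM
compound 2 `CCC[C@@H]1O[C@H](COCc2ccccc2)[C@@H](OCc2ccccc2)[C@H](OCc2ccccc2)[C@@H]1O` gives 23300 nM

In a functional assay on HeLa cells (Homo sapiens) for antiproliferative activity, read by sulforhodamine B assay (a lower number here means a stronger inhibitor of growth, a higher number a weaker inhibitor of growth), compound 1 gives 18900 nM and compound 2 gives 23300 nM. Within the data shown here, the two are related by the fact that compounds 1 and 2 differ only in the configuration as drawn; the step of a 1.2-fold higher number from compound 1 to compound 2 (0.09 log units; within the scatter) is within the scatter, so compound 1 stands at the same level as the only other measured compound, and the two numbers give no direction to lean on.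

Compound 3 `O[C@@H]1[C@@H](OCc2ccccc2)[C@H](OCc2ccccc2)[C@@H](COCc2ccccc2)O[C@H]1Cc1ccccc1` differs from compound 1 by phenyl in place of ethyl on a saturated chain carbon bound to a saturated ring carbon. Among the measured compounds shown here, no measured step touches this change: the single step in hand, from compound 1 to compound 2, alters configuration only and leaves the propyl group untouched, so it carries no information about propyl to benzyl. With nothing in the measured data pointing one way or the other, the expectation for compound 3 is a number near that of compound 1, with the step of a 1.2-fold lower number from compound 1 to compound 3 (0.07 log units; within the scatter) expected to lie within the scatter, and with a wide range to reflect the absence of a guiding step. Compound 3 is estimated at 16000 nM, in the range 5000 nM to 50000 nM.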

Compound 3, concentration for 50% growth inhibition: 17400 nM
Compound 3: the middle estimate sits 1.1-fold (0.04 log units) below what was measured, within the range that was stated.
By their numbers in this assay, from the lowest: compounds 3, 1 and 2 (each within the scatter of the next).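

In this assay, the step at this position, propyl to benzyl on the shared core, reads as a 1.1-fold lower number from compound 1 to compound 3 (0.04 log units; within the scatter). Among these compounds, this is the first information on this position: a six-membered aromatic ring of carbon only can enter on a saturated chain carbon bound to a saturated ring carbon without moving the number beyond the scatter, something the earlier pair could not show, as it differs in configuration only and keeps the propyl group in both compounds. Nothing in hand bears on why the number stays level across this change.

Two compounds joined by one step cannot say whether the position is indifferent to its substituent in general or whether benzyl merely happens to match propyl, so groups of another kind there, such as an amine, a carboxylic acid or a longer chain, remain an open question. Among the compounds shown here, also open is whether propyl to benzyl reads the same on the configuration of compound 2, since the single step here rests on the configuration of compound 1.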